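Notes on swapping the sulfur-bound aryl group in compound 1

The compounds below may be only part of what the source reports. "The series", "measured", "known", "first", "only" and "open" are said of these compounds alone.

Measured in a functional assay on A549 cells (Homo sapiens) for inhibition, read by CCK-8 assay, with a stated time of 72 h, tested at 8 uM; on this read-out lower numbers stand for less inhibition of growth and higher numbers for more inhibition of growth at the one concentration tested:
- compound 1 `Cc1cc(C)cc(SCc2ccc(/C=C/C(=O)Nc3ccccc3N)cc2)c1`: 47.3%
- compound 2 `COc1ccc(SCc2ccc(C(=O)Nc3ccccc3N)cc2)cc1`: 70.7%
- compound 3 `CCc1ccc(SCc2ccc(C(=O)Nc3ccccc3N)cc2)cc1`: 91.4%

Compound 1 has the lowest number of the three, and compound 2 and compound 3 both lie above it beyond the usual scatter. Unmeasured compound 4 `Nc1ccccc1NC(=O)/C=C/c1ccc(CSc2ccc(C(F)(F)F)cn2)cc1` keeps the core of compound 1 and changes only the group on sulfur: 5-(trifluoromethyl)pyridin-2-yl in place of 3,5-dimethylphenyl on a sulfur.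

Going by the values given here, only one measured step offers any guide: a number 20.7 percentage points higher from compound 2 to compound 3 (beyond the scatter). That step is a different exchange on a different core, so it bears on compound 4 only loosely. It shows that a single change of group can move this read-out by a modest amount. Among the compounds with values here, it gives no direction for a change from 3,5-dimethylphenyl to 5-(trifluoromethyl)pyridin-2-yl, and no measured pair covers that exchange. A step of similar modest size is therefore possible either way, and the value of compound 1 remains the best starting point.

The expected net change, a number 2.7 percentage points higher from compound 1 to compound 4 (within the scatter), is accordingly small, with no firm direction. For compound 4 the estimated value in this assay is 50%, with an expected range of 25% to 75%.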

Compound 4, percent growth inhibition at one concentration: 56.5%
Compound 4: the middle estimate sits 6.5 percentage points below what was measured; low and high end bracket the measured number.
By their numbers in this assay, from the lowest: compounds 1 and 4 (each within the scatter of the next); then compound 2; then compound 3.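

In this assay, the first exchange read at this position on the core of compound 1 gives a number 9.2 percentage points higher from compound 1 to compound 4 (within the scatter), so the read-out does not separate these two compounds. On a sulfur whose other neighbour is a saturated chain carbon, a ring of carbon only with no hydrogen-bond acceptor can thus give way to a ring with one hetero atom and one hydrogen-bond acceptor, and a larger group of 10 heavy atoms, without a change beyond the scatter, whereas the exchange on the other core gave a number 20.7 percentage points higher from compound 2 to compound 3 (beyond the scatter). Nothing available bears on why this exchange leaves the two compounds inseparable.

The compounds shown leave open whether the aryl groups of compound 2 and compound 3 would give the same spread on the core of compound 1, so the effect of the core itself cannot yet be separated from that of the group on sulfur. They also leave open how a group of another kind on the sulfur-bound ring, such as an amine, a carboxylic acid or a morpholine, would read in this assay, and whether a plain alkyl chain on sulfur could replace the aromatic ring at all.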